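Phenyl for Ethyl on the Ring Nitrogen of Compound 3

The source may hold more compounds than are shown below. What is called first, only, known or untested is meant among the compounds shown, and "the series" means these compounds.

Compound 3 `CCn1c(SCC(=O)c2ccccc2)nnc1-c1ccccc1` gives 51% in a functional assay on the whole organism (strain albino) for inhibition, with Rattus norvegicus as the target, read by paw edema, with a stated time of 5 h, at a dose of 0.28 mmol/kg by the oral route; on this read-out higher numbers stand for more inhibition at the one dose given (going by the name of the read-out) and lower numbers for less inhibition. Its number sits within the scatter of compound 1 `COc1ccc(-c2nnc(SCC(=O)c3ccccc3)n2-c2ccccc2)cc1OC`, which in this assay gives 59%. Beyond the scatter above compound 3 lies compound 2 `O/N=C(/CSc1nnc(-c2ccccc2)n1-c1ccccc1)c1ccccc1`, which in this assay gives 75%. Compound 4 `O=C(CSc1nnc(-c2ccccc2)n1-c1ccccc1)c1ccccc1` differs from compound 3 by phenyl in place of ethyl on an aromatic nitrogen. Compounds 1 and 2 both carry a phenyl on that aromatic nitrogen, and their numbers lie at or above that of compound 3, so in this assay a small rise is expected for compound 4, with the step of a number 9 percentage points higher from compound 3 to compound 4 (within the scatter) likely close to the scatter. Compound 4 is therefore estimated to give 60% in this assay, expected between 45% and 75%.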

Compound 4, a percentage reported as inhibition, in the whole organism at one dose (the size of the read-out at that dose, not a potency): 63%
The estimate for compound 4 lay 3 percentage points below the measured number; low and high end bracket the measured number.
By their numbers in this assay, from the lowest: compounds 3, 1 and 4 (each within the scatter of the next, the first and the last beyond it); then compound 2.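

In this assay, among the compounds shown here, phenyl in place of ethyl on the aromatic nitrogen gives a number 12 percentage points higher from compound 3 to compound 4 (beyond the scatter) as the first direct reading at this position. With that phenyl kept, the group of 8 heavy atoms in place of the group of 9 heavy atoms on the saturated chain carbon bound to a sulfur gives a number 12 percentage points lower from compound 2 to compound 4 (beyond the scatter) while phenyl in place of 3,4-dimethoxyphenyl on an aromatic carbon gives a number 4 percentage points higher from compound 1 to compound 4 (within the scatter) as the smallest of the three steps. Nothing measured here accounts for these steps. From the compounds shown here alone, whether a benzyl or a longer chain such as butyl on that nitrogen would read nearer to ethyl or to phenyl stays open, as does the effect of a carboxylic acid on the phenyl there.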